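Bromo to methoxy on the aryl ring, from compound 3 to compound 4

The source may hold more compounds than are shown below. What is called first, only, known or untested is meant among the compounds shown, and "the series" means these compounds.

Compound 1, `COc1ccc(/C(Cl)=C/C=C(\C#N)C(=O)c2c[nH]c3ccccc23)cc1`: 23.4%
Compound 2, `COc1cc(/C(Cl)=C/C=C(\C#N)C(=O)c2c[nH]c3ccccc23)cc(OC)c1OC`: 21.1%
Compound 3, `N#C/C(=C\C=C(/Cl)c1ccc(Br)cc1)C(=O)c1c[nH]c2ccc(Br)cc12`: 15.8%

Of the compounds shown here, three have been tested in a functional assay for inhibition, with a stated time of 30 min, tested at 1 mM; on this read-out higher numbers stand for more inhibition at the one concentration tested (going by the name of the read-out) and lower numbers for less inhibition. Compound 1 gives 23.4%, compound 2 gives 21.1% and compound 3 gives 15.8%. The number for compound 3 lies within the usual scatter of both compound 2 and compound 1, so on this assay the three cannot be told apart, and none of them can be said to give a higher or lower number than the others.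

Compound 4, `COc1ccc(/C(Cl)=C/C=C(\C#N)C(=O)c2c[nH]c3ccc(Br)cc23)cc1`, has not yet been measured. It differs from compound 3 in one place: methoxy in place of bromo on an aromatic carbon. Within the data shown here, no pair of measured compounds differs in a single place, so no measured step shows what this change does. What the numbers do show is that compound 1, which carries the methoxy group, and compound 3, which carries the bromo group, give values within the scatter of each other.

Compound 4 is therefore expected to give 20% in this assay, within a range from 8% to 32%. The step that this estimate means, a number 4.2 percentage points higher from compound 3 to compound 4 (within the scatter), is expected to stay within the scatter of repeated measurements, with no direction that can be trusted.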

Compound 4, a percentage reported as inhibition, at one concentration (the size of the read-out at that concentration, not a potency): 15.6%
Compound 4: the middle estimate sits 4.4 percentage points above what was measured; low and high end bracket the measured number.
By their numbers in this assay, from the lowest: compounds 4, 3, 2 and 1 (each within the scatter of the next).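

The change from 4-bromophenyl to 4-methoxyphenyl now has its own measured step in this assay (a number 0.2 percentage points lower from compound 3 to compound 4 (within the scatter)), so with the rest of the structure held fixed, bromo and methoxy on this aromatic carbon cannot be told apart. Bromo in place of hydrogen on an aromatic carbon, the other single change now readable, also gives no clear difference (a number 7.8 percentage points lower from compound 1 to compound 4 (within the scatter)). No independent measurement is available to explain either result.

Going by these compounds, since each of the four compounds lies within the scatter of the next at the one concentration tested, it remains open whether any group at this position can move the read-out at all. Whether an amine or a carboxylic acid in place of the methoxy would give a number beyond the scatter is a question these compounds do not answer.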